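The source may report more compounds than this note shows. Statements on the series, on what has been measured and on what is new or still open speak of the compounds shown alone.

The measured compounds, each in an ADME assay on Vero cells (Chlorocebus sabaeus) for cytotoxicity, read by MTT assay, with a stated time of 72 h; a lower number here means that less compound is tolerated, a higher number that more compound is tolerated:

Compound 1, `COc1c(N2C[C@H]3CCCN(Cc4cn(CCCN5C(=O)/C(=N/O)c6cc(C)ccc65)nn4)[C@H]3C2)c(F)cc2c(=O)c(C(=O)O)cn(C3CC3)c12`: 8 ug/mL
Compound 2, `CCO/N=C1/C(=O)N(CCCn2cc(CN3CCC[C@@H]4CN(c5c(F)cc6c(=O)c(C(=O)O)cn(C7CC7)c6c5OC)C[C@@H]43)nn2)c2ccc(C)cc21`: 4 ug/mL
Compound 3, `CCO/N=C1/C(=O)N(CCCn2cc(CN3CCC[C@@H]4CN(c5c(F)cc6c(=O)c(C(=O)O)cn(C7CC7)c6c5OC)C[C@@H]43)nn2)c2ccc(F)cc21`: 4 ug/mL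

Compound 3 stands level with compound 2 at the digits printed, and the two together hold the lowest numbers of the three; compound 1 is furthest, though a 2.0-fold higher number from compound 2 to compound 1 (0.30 log units; within the scatter). That step is the change (hydrogen in place of ethyl on an oxygen). The change fluoro in place of methyl on an aromatic carbon gave no change at the digits printed from compound 2 to compound 3 (within the scatter).

Compound 4, `COc1c(N2C[C@H]3CCCN(Cc4cn(CCCN5C(=O)/C(=N/O)c6cc(F)ccc65)nn4)[C@H]3C2)c(F)cc2c(=O)c(C(=O)O)cn(C3CC3)c12`, has not yet been measured in this assay. It differs from compound 3 by hydrogen in place of ethyl on an oxygen, and this is the same change as that from compound 2 to compound 1, with the place described in the same words for both; only the cores differ, by fluoro in place of methyl on an aromatic carbon. Because the earlier instance gave a 2.0-fold higher number from compound 2 to compound 1 (0.30 log units; within the scatter), a step of similar size, a 1.8-fold higher number from compound 3 to compound 4 (0.24 log units; within the scatter), is expected here. Compound 4 is therefore estimated to give 7 ug/mL in this assay, with a likely range from 3 ug/mL to 14 ug/mL.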

Compound 4, half-maximal cytotoxic concentration: 2 ug/mL
Compound 4: the middle estimate sits 3.5-fold (0.54 log units) above what was measured, outside the stated range (below it).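

Hydrogen in place of ethyl on an oxygen gave a 2.0-fold lower number from compound 3 to compound 4 (0.30 log units; within the scatter), and in this assay this does not repeat the earlier step, so the change cannot be carried from one core to the other as a fixed step: the same change on two cores in this assay, a 2.0-fold higher number (0.30 log units; within the scatter) from compound 2 to compound 1 and a 2.0-fold lower number (0.30 log units; within the scatter) from compound 3 to compound 4, 4.0-fold (0.60 log units) apart, beyond the scatter of two such steps Read the other way round, fluoro in place of methyl on an aromatic carbon gave a 4.0-fold lower number from compound 1 to compound 4 (0.60 log units; beyond the scatter), which also departs from its earlier instance: the same change on two cores in this assay, no change at the digits printed (within the scatter) from compound 2 to compound 3 and a 4.0-fold lower number (0.60 log units; beyond the scatter) from compound 1 to compound 4, 4.0-fold (0.60 log units) apart, beyond the scatter of two such steps These two comparisons rest on the same four compounds, so they show that the two changes did not add up independently in this set, but they do not show why, or whether this would hold elsewhere in the series, and each ethoxy to hydroxy step taken alone stays within the scatter.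

The compounds shown leave open what other groups on that oxygen would do, such as methyl or a longer chain. They also leave open whether chloro or hydrogen on the aromatic carbon would behave like fluoro or like methyl.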